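A few compounds are considered here, and "the series" means these few. Any claim that something is new, unique, unknown or untested is made for them only; others in the source may bear on it.

Measured compounds in an assay on CHO cells for agonist activity at 5-hydroxytryptamine receptor 1D (Homo sapiens), read by GTPgammaS binding; on this read-out lower numbers stand for an effect already at smaller amounts and higher numbers for an effect only at larger amounts of compound:
- compound 1 `c1ccc2c(c1)CCC2NC1CCN(CCCc2c[nH]c3ccc(-n4cnnc4)cc23)CC1`: 25 nM
- compound 2 `O=S(=O)(NCC1CCN(CCCc2c[nH]c3ccc(-n4cnnc4)cc23)CC1)c1ccccc1`: 12 nM
- compound 3 `COC[C@H](NC1CCN(CCCc2c[nH]c3ccc(Cn4cncn4)cc23)CC1)c1ccc(F)cc1`: 8.9 nM

Compound 1 has the highest number of the three; compound 2 sits nearest with a 2.1-fold lower number from compound 1 to compound 2 (0.32 log units; beyond the scatter), and compound 3 furthest, its value simply being lower than that of compound 1. Compound 4 `CC(C)=CCN(C)C1CCN(CCCc2c[nH]c3ccc(-n4cnnc4)cc23)CC1` differs from compound 1 by methyl(3-methylbut-2-en-1-yl)amino in place of (2,3-dihydro-1H-inden-1-yl)amino on a saturated ring carbon. For the measured compounds named here, the only step that bears on this change is the one from compound 1 to compound 2, where the same leaving group was exchanged for a different substituent and the number fell modestly. The entering group here is smaller and carries no donor, so a step of similar size, downward or none beyond the scatter, is expected, a 1.7-fold lower number from compound 1 to compound 4 (0.22 log units; within the scatter). Compound 4 is therefore estimated at 15 nM, within 6 nM to 40 nM.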

Compound 4, half-maximal effective concentration: 1.8 nM
Beside the measured number, compound 4's estimate is 8.3-fold (0.92 log units) above it; the whole stated range lies above it.
By their numbers in this assay, from the lowest: compound 4; then compounds 3 and 2 (each within the scatter of the next); then compound 1.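

At this saturated ring carbon, this assay shows a 14-fold lower number from compound 1 to compound 4 (1.14 log units; beyond the scatter) when methyl(3-methylbut-2-en-1-yl)amino, which has no ring, enters for (2,3-dihydro-1H-inden-1-yl)amino. The same group also gives a 6.7-fold lower number from compound 2 to compound 4 (0.82 log units; beyond the scatter) so among these substituents on the shared core, the one without a ring gives the lowest number. No measurement here accounts for this change.

The compounds shown leave open whether the double bond or the methyl on the amine nitrogen matters for the drop. A saturated 3-methylbutyl chain on the same amine, or the same amine without its methyl, would separate the two.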